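Configuration step from compound 3 to compound 4

The source may report more compounds than this note shows. Statements on the series, on what has been measured and on what is new or still open speak of the compounds shown alone.

Compound 1 `Cc1nn(C[C@@H]2CO[C@H](CO)O2)c(=O)[nH]c1=O`, compound 2 `Cc1nn(C[C@H]2CO[C@H](CO)O2)c(=O)[nH]c1=O` and compound 3 `Cc1nn(C[C@H]2CO[C@@H](CO)O2)c(=O)[nH]c1=O` share the same atoms and bonds. In a functional assay on CCRF-CEM cells (Homo sapiens) (on this read-out lower numbers stand for an effect already at smaller amounts and higher numbers for an effect only at larger amounts of compound), compound 1 gives > 100000 nM, a limit and not a number. In this assay compound 2 gives > 100000 nM, again a limit. In this assay compound 3 gives > 100000 nM, so it too stands only at a limit.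

Compound 4 `Cc1nn(C[C@@H]2CO[C@@H](CO)O2)c(=O)[nH]c1=O` follows from compound 3 through (the two compounds have the same atoms and bonds and differ only in configuration as drawn: 1 of 2 stereo elements differ; a stereocentre at a saturated ring carbon is drawn S in compound 3 and R in compound 4).

Three measured steps are of the same configuration-only kind: a step that the two limits leave unreadable from compound 1 to compound 2, a step that the two limits leave unreadable from compound 1 to compound 3 and a step that the two limits leave unreadable from compound 2 to compound 3. None has a readable size because of the limit of > 100000 nM in this assay, at which 3 of the 3 values shown sit. They therefore offer no measured size to carry over, but none of these configurations gives a number in this assay. Taking a step that the two limits leave unreadable from compound 2 to compound 3 as the closest guide, a single inverted stereocentre, no step beyond the scatter is expected, and a further limit is the likely report.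

The expected step is a number no higher from compound 3 to compound 4 (the limit leaves the size open).

Compound 4 is estimated at 100000 nM, with an expected range of 50000 nM to 200000 nM.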

Compound 4, half-maximal effective concentration: > 100000 nM
Compound 4: a limit, no number; the forecaster's own chance of this, stated with the estimate: 90%; the middle value sits exactly at the limit.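

In this assay compound 4 gives > 100000 nM, again a limit and not a number. The steps linking compound 4 to compound 1, compound 2 and compound 3 cannot be read. The compounds shown leave open whether configuration at either stereocentre has any effect on this read-out: the limit of > 100000 nM in this assay, at which 4 of the 4 values shown sit.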